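This account rests on a few compounds, and the source may have more. Where it says the series, first, only, none or still open, it means among the compounds named here.

In an ADME assay on L929 cells (Mus musculus, culture collection number NCTC 929) for cytotoxicity, read by MTT assay, with a stated time of 72 h (a higher number here means a weaker inhibitor, a lower number a stronger inhibitor), compound 3 `CCCCCCCCCCCCCCCC(=O)c1c(O)cc(C)oc1=O` gives 165000 nM, within the scatter of compound 1 `Cc1cc(O)c(C(=O)CCC2CCCCC2)c(=O)o1` at 117000 nM. Compound 2 `CCCCCC(=O)c1c(O)cc(C)oc1=O` is reported only as a limit, > 200000 nM. Compound 4 `CCCCCCCC(=O)c1c(O)cc(C)oc1=O` differs from compound 3 by hydrogen in place of octyl on a saturated chain carbon, seven bonds along the chain from a carbonyl carbon. For the measured compounds named here, the only measured step bearing on this is another change in the chain, an at least 1.7-fold higher number from compound 1 to compound 2 (0.23 log units; that floor lies within the scatter). With that step as the guide, no shift beyond the scatter is expected in this assay, although a result reported only as a limit is possible. The estimated change is a 1.2-fold higher number from compound 3 to compound 4 (0.06 log units; within the scatter), which stays within the scatter. For compound 4 the estimated value is 190000 nM, with an expected range of 120000 nM to 300000 nM.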

Compound 4, half-maximal inhibitory concentration: 140000 nM
Beside the measured number, compound 4's estimate is 1.4-fold (0.13 log units) above it; the range from low to high includes it.
By their numbers in this assay, from the lowest: compounds 1, 4 and 3 (each within the scatter of the next). At a limit, above all of these: compound 2.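

In this assay, hydrogen in place of octyl on a saturated chain carbon, seven bonds along the chain from a carbonyl carbon, gives a 1.2-fold lower number from compound 3 to compound 4 (0.07 log units; within the scatter). Ethyl in place of hydrogen, five bonds along the chain, gives an at least 1.4-fold lower number from compound 2 to compound 4 (0.15 log units; that floor lies within the scatter), and pentyl in place of cyclohexyl, two bonds along the chain, gives a 1.2-fold higher number from compound 1 to compound 4 (0.08 log units; within the scatter), so none of these chain changes is shown beyond the scatter. Compound 2 is held only as a limit: the limit of > 200000 nM in this assay, at which 1 of the 4 values shown sits.

Going by these compounds, whether an amine or a carboxylic acid on the chain would give a number beyond the scatter remains open. Changes to the shared core also remain open.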